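This account rests on a few compounds, and the source may have more. Where it says the series, first, only, none or still open, it means among the compounds named here.

Three compounds have been measured in an assay on CHO-K1 cells for antagonist activity at transient receptor potential cation channel subfamily V member 1 (Homo sapiens), read by FLIPR; a higher number here means a weaker inhibitor, a lower number a stronger inhibitor:
compound 1, `CCCCCSc1nc(C(F)(F)F)ccc1CNC(=O)C(C)c1ccc(NS(C)(=O)=O)c(F)c1`, 2.5 nM
compound 2, `CC(C(=O)NCc1ccc(C(F)(F)F)nc1SCCCN1CCCCC1)c1ccc(NS(C)(=O)=O)c(F)c1`, 3 nM
compound 3, `CC1CCN(CCCSc2nc(C(F)(F)F)ccc2CNC(=O)C(C)c2ccc(NS(C)(=O)=O)c(F)c2)CC1`, 2.9 nM

Compound 3 stands second highest of these three numbers in this assay; its nearest neighbour is compound 2, and the gap a 1.0-fold lower number from compound 2 to compound 3 (0.01 log units; within the scatter) is within the scatter, as is the gap a 1.2-fold higher number from compound 1 to compound 3 (0.06 log units; within the scatter). All three sit within the scatter of one another, so none of them can be called stronger or weaker than the rest.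

Compound 4, `COC(=O)CCSc1nc(C(F)(F)F)ccc1CNC(=O)C(C)c1ccc(NS(C)(=O)=O)c(F)c1`, is not yet measured. It differs from compound 3 by methoxycarbonyl in place of (4-methylpiperidin-1-yl)methyl on a saturated chain carbon, two bonds along the chain from a sulfur. The measured steps bear on this change: a 1.2-fold higher number from compound 1 to compound 2 (0.08 log units; within the scatter) and a 1.2-fold higher number from compound 1 to compound 3 (0.06 log units; within the scatter) show that exchanging ethyl for piperidin-1-yl or 4-methylpiperidin-1-yl, three bonds along the chain from a sulfur, left the number essentially unchanged, and a 1.0-fold lower number from compound 2 to compound 3 (0.01 log units; within the scatter) did the same. Going by the values given here, compound 4 goes further: methoxycarbonyl, with no ring, replaces the whole (4-methylpiperidin-1-yl)methyl, and no measured compound covers that. On this evidence the step of a 1.6-fold higher number from compound 3 to compound 4 (0.19 log units; within the scatter) is expected to stay within the scatter or reach only a little beyond it. Compound 4 is therefore estimated at about 4.5 nM, with a range from 1.5 nM to 14 nM.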

Compound 4, inhibition constant: 48.2 nM
The estimate for compound 4 lay 11-fold (1.03 log units) below the measured number; measured number above the stated range.
By their numbers in this assay, from the lowest: compounds 1, 3 and 2 (each within the scatter of the next); then compound 4.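

The earlier compounds shown here made this chain look forgiving in this assay, but methoxycarbonyl breaks that picture: a 17-fold higher number from compound 3 to compound 4 (1.22 log units; beyond the scatter) and a 16-fold higher number from compound 2 to compound 4 (1.21 log units; beyond the scatter) and a 19-fold higher number from compound 1 to compound 4 (1.29 log units; beyond the scatter) are all large and beyond the scatter. The position therefore accepts an end without a ring as well as piperidin-1-yl and 4-methylpiperidin-1-yl, yet it does not accept every group, and compound 4 alone stands apart from the other three. The change is also more than a swap at the chain end: (3-(4-methylpiperidin-1-yl)propyl)sulfanyl gives way to (2-(methoxycarbonyl)ethyl)sulfanyl, so the end group and the chain length change together.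

Nothing available here explains this drop. The compounds shown leave open whether the loss follows the methoxycarbonyl group or the shorter chain, and a longer chain ending in methoxycarbonyl, or a carboxylic acid or an amine on the same short chain, would help to separate the two.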